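The compounds below may be only part of what the source reports. "The series", "measured", "known", "first", "only" and "open" are said of these compounds alone.

Compound 3 `Cc1ccc(CNC(=O)c2cccc(C(C)Oc3cccnc3Nc3ncc(C)s3)c2)cc1` carries a 5-methyl-1,3-thiazol-2-yl group on the ring nitrogen and a 4-methylbenzyl amide. In a functional assay on HCC78 cells (Homo sapiens) for antiproliferative activity, read by MTT assay, with a stated time of 48 h (on this read-out higher numbers stand for weaker inhibition and lower numbers for stronger inhibition), compound 3 gives 14800 nM. Compound 1 `CC(Oc1cccnc1Nc1cnn(C)c1)c1cccc(C(=O)NCc2ccc(F)c(Cl)c2)c1` gives 7800 nM in this assay, and the two numbers lie within the usual scatter of each other. Compound 2 `Cc1ccc(CNC(=O)c2cccc(C(C)Oc3cccnc3Nc3ncccn3)c2)cc1` gives only a limit of the assay, > 100000 nM, as noted in the limit of > 100000 nM in this assay, at which 1 of the 3 values shown sits. Within the data shown here, the one measured step, an at least 6.7-fold lower number from compound 2 to compound 3 (0.82 log units; beyond the scatter), concerns the group on the ring nitrogen and not the amide side.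

Compound 4 `Cc1cnc(Nc2ncccc2OC(C)c2cccc(C(=O)NCc3ccc(F)c(Cl)c3)c2)s1` differs from compound 3 in exactly that other place: 3-chloro-4-fluorophenyl in place of 4-methylphenyl on a saturated chain carbon bound to an amide-type nitrogen. Among the measured compounds shown here, no measured step covers this exchange. What the numbers do show is that compound 1, which already carries the 3-chloro-4-fluorobenzyl amide with a different group on the ring nitrogen, and compound 3 sit within the scatter of each other, so the amide-side change gives no sign of moving the number far. In this assay compound 4 is therefore expected to show no step beyond the scatter, a 1.5-fold lower number from compound 3 to compound 4 (0.17 log units; within the scatter). The estimate for compound 4 is 10000 nM, with a range from 3000 nM to 40000 nM.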

Compound 4, half-maximal inhibitory concentration: 34700 nM
Compound 4: the middle estimate sits 3.5-fold (0.54 log units) below what was measured, and the stated range covers the measured number.
By their numbers in this assay, from the lowest: compounds 1 and 3 (each within the scatter of the next); then compound 4. At a limit, above all of these: compound 2.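

In this assay, the exchange on the saturated chain carbon bound to an amide-type nitrogen now has a measured size: with the 5-methyl-1,3-thiazol-2-yl group held fixed, 3-chloro-4-fluorophenyl in place of 4-methylphenyl gives a 2.3-fold higher number from compound 3 to compound 4 (0.37 log units; beyond the scatter). With the 3-chloro-4-fluorobenzyl amide held fixed, the group on the ring nitrogen also moves the number, as 5-methyl-1,3-thiazol-2-yl in place of 1-methyl-1H-pyrazol-4-yl gives a 4.4-fold higher number from compound 1 to compound 4 (0.65 log units; beyond the scatter), so the closeness of compound 1 and compound 3 did not mean that either change alone leaves the number unmoved. Nothing shown here gives a cause for either step.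

Whether the amide-side step holds with 1-methyl-1H-pyrazol-4-yl on the ring nitrogen stays open, since the compounds shown include no partner of compound 1 with the 4-methylbenzyl amide. Also open is how a plain benzyl amide, or a benzyl amide carrying a methoxy group, would compare with the two benzyl amides shown.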